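A few compounds are considered here, and "the series" means these few. Any claim that something is new, unique, unknown or untested is made for them only; others in the source may bear on it.

Working notes on a three-compound series, extended by one.

Compound 3 `O=S(=O)(c1ccc(F)cc1)c1cnc2cc(F)ccc2c1-c1ccc(F)cc1` gives 1.34 mL/min in an ADME assay on microsomes from liver (Homo sapiens) for metabolic stability, tested at 2.5 uM; on this read-out higher numbers stand for fast clearance and lower numbers for slow clearance. Compound 1 `O=S(=O)(c1ccc(F)cc1)c1cnc2cc(F)ccc2c1-c1cccc(F)c1` differs from compound 3 by 3-fluorophenyl in place of 4-fluorophenyl on an aromatic carbon, and in this assay compound 1 gives 0.95 mL/min, a step of a 1.4-fold lower number from compound 3 to compound 1 (0.15 log units; within the scatter). Compound 2 `O=S(=O)(c1cc(Cl)cc(Cl)c1)c1cnc2cc(F)ccc2c1-c1ccc(F)cc1` differs from compound 3 by 3,5-dichlorophenyl in place of 4-fluorophenyl on a sulfonyl sulfur; in this assay compound 2 gives 0.18 mL/min, and the step from it to compound 3 is a 7.4-fold higher number from compound 2 to compound 3 (0.87 log units; beyond the scatter).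

Compound 4 `O=S(=O)(c1cc(Cl)cc(Cl)c1)c1cnc2cc(F)ccc2c1-c1cccc(F)c1` is not yet measured. It differs from compound 2 by 3-fluorophenyl in place of 4-fluorophenyl on an aromatic carbon, the same change seen from compound 3 to compound 1, and in this assay that step was a 1.4-fold lower number from compound 3 to compound 1 (0.15 log units; within the scatter).

From compound 2 to compound 4 a step of a 1.2-fold lower number from compound 2 to compound 4 (0.08 log units; within the scatter) is expected, resting on the earlier step of a 1.4-fold lower number from compound 3 to compound 1 (0.15 log units; within the scatter) having stayed within the scatter. Compound 4 is estimated at 0.15 mL/min, between 0.08 mL/min and 0.35 mL/min.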

Compound 4, intrinsic clearance in a liver preparation (reported as CLH), per the amount of preparation that the assay uses: 0.41 mL/min
Estimate against measurement, compound 4: 2.7-fold (0.44 log units) below, outside the stated range (above it).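

In this assay, the change from 4-fluorophenyl to 3-fluorophenyl on the aromatic carbon does not carry unchanged from one core to the other, with a 2.3-fold higher number from compound 2 to compound 4 (0.36 log units; beyond the scatter) not repeating the earlier step: the same change on two cores in this assay, a 1.4-fold lower number (0.15 log units; within the scatter) from compound 3 to compound 1 and a 2.3-fold higher number (0.36 log units; beyond the scatter) from compound 2 to compound 4, 3.2-fold (0.51 log units) apart, beyond the scatter of two such steps

The change on the sulfonyl sulfur keeps its direction, with a 2.3-fold lower number from compound 1 to compound 4 (0.36 log units; beyond the scatter), but not its size: the same change on two cores in this assay, a 7.4-fold higher number (0.87 log units; beyond the scatter) from compound 2 to compound 3 and a 2.3-fold higher number (0.36 log units; beyond the scatter) from compound 4 to compound 1, 3.2-fold (0.51 log units) apart, beyond the scatter of two such steps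

Within these four compounds, neither step size can be transferred to the other core, though the data show only that the two changes are not independent, not the reason for it.

Still open, going by these compounds, is whether this dependence appears with a methoxy group or an amine in place of the fluorine on either aryl ring, or with a single chlorine on the sulfonyl aryl ring.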